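A Ring-Nitrogen Methyl and Its Cost in Binding

This account rests on a few compounds, and the source may have more. Where it says the series, first, only, none or still open, it means among the compounds named here.

Measured compounds:
- Compound 1, `COc1cc(C2=CC3CC(C2)CN(C)C3)cnc1Cl`: 1430 nM
- Compound 2, `COc1cc(C2=CC3CNCC(C2)C3)cnc1Cl`: 7 nM
- Compound 3, `CC(C)Oc1cncc(C2=CC3CNCC(C2)C3)c1`: 4.8 nM

All three were tested in an in vitro assay on SH-SY5Y cells for displacement of a labelled ligand from Neuronal acetylcholine receptor; alpha3/beta4 (Homo sapiens); on this read-out lower numbers stand for stronger inhibition and higher numbers for weaker inhibition. Compound 2 and compound 3 sit close together there, and their gap lies within the ordinary scatter of this kind of measurement, so no order between them can be read. How the cores of compound 2 and compound 3 differ is not broken down here.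

Compound 1 stands apart. It differs from compound 2 in a single place: methyl in place of hydrogen on an amine nitrogen in a ring. That one change brings a 200-fold higher number from compound 2 to compound 1 (2.31 log units; beyond the scatter), a very large step for such a small addition.

Compound 4, `CC(C)Oc1cncc(C2=CC3CC(C2)CN(C)C3)c1`, has not yet been measured. It relates to compound 3 exactly as compound 1 relates to compound 2: methyl in place of hydrogen on an amine nitrogen in a ring. The place of the change is the same in both pairs, so this is the same change, made on a different core.

Among the measured compounds shown here, with only one earlier example of this change, the expectation for compound 4 rests on that single step. Because compound 2 moving to compound 1 gave a 200-fold higher number from compound 2 to compound 1 (2.31 log units; beyond the scatter), compound 4 is expected to lie well above compound 3, with an estimated step of a 190-fold higher number from compound 3 to compound 4 (2.27 log units; beyond the scatter). Compound 4 is therefore estimated at 900 nM in this assay, most likely between 250 nM and 3500 nM.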

Compound 4, inhibition constant: 1730 nM
Compound 4: middle estimate off by 1.9-fold (0.28 log units), on the low side; measured number inside the range.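

The methyl in place of hydrogen on an amine nitrogen in a ring again carries a heavy cost in this assay and brings a 360-fold higher number from compound 3 to compound 4 (2.56 log units; beyond the scatter) on this second core. Set side by side, the two steps cannot be told apart, so in this series the change carries over from one core to the other with much the same large size: the same change on two cores in this assay, a 200-fold higher number (2.31 log units; beyond the scatter) from compound 2 to compound 1 and a 360-fold higher number (2.56 log units; beyond the scatter) from compound 3 to compound 4, 1.8-fold (0.25 log units) apart, within the scatter of two such steps. Among the compounds shown here, this is still only two pairs of compounds, so it does not show that the step would keep its size on every other core, and it gives no reason why so small an addition costs so much.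

The compounds shown leave open what a group other than methyl on that same nitrogen would do, for example whether an ethyl group, a longer chain or an acetyl group would land near the methyl compounds or nearer those with hydrogen. Also open, going by these compounds, is whether the step would stay this large on a further core, for instance one carrying a nitrile.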